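Triazene Half-Life in Buffer: Bromo to Ethoxycarbonyl

The source may hold more compounds than are shown below. What is called first, only, known or untested is meant among the compounds shown, and "the series" means these compounds.

Compound 1, `Cc1ccc(/N=N/N(C)C(=O)NCCSc2ccc(O)cc2)cc1`: in this study a limit only, > 240 h
Compound 2, `CN(/N=N/c1ccc(Br)cc1)C(=O)CCc1ccc(O)cc1`: 106 h

Of the compounds shown here, two have been measured in a physicochemical assay for pharmacokinetics, read by HPLC, in phosphate buffer, at pH 7.4; on this read-out lower numbers stand for a shorter-lived compound and higher numbers for a longer-lived compound. For compound 1 the result is a limit of the assay, > 240 h. For the measured compounds named here, compound 2, with 106 h, therefore supplies the only number among the two results; the other result sits at the limit of > 240 h in this assay, at which 1 of the 2 values shown sits. Going by the values given here, no two measured compounds differ in one place, so no measured step is available.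

Compound 3, `CCOC(=O)c1ccc(/N=N/N(C)C(=O)CCc2ccc(O)cc2)cc1`, has not yet been measured in this assay. It differs from compound 2 by ethoxycarbonyl in place of bromo on an aromatic carbon. Among the compounds with values here, with no measured step of this kind to rely on, the expected size of the change from compound 2 to compound 3 is modest and within or only slightly beyond the usual scatter; the estimated step is a 1.4-fold higher number from compound 2 to compound 3 (0.15 log units; within the scatter). Compound 3 is accordingly expected to give 150 h, with a range from 60 h to 300 h.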

Compound 3, half-life: 130 h
Compound 3: the middle estimate sits 1.2-fold (0.06 log units) above what was measured, and the stated range covers the measured number.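

For the compounds shown here, the pair gives the first measured step in this assay: ethoxycarbonyl in place of bromo on an aromatic carbon, para to a large group, amounts to a 1.2-fold higher number from compound 2 to compound 3 (0.09 log units; within the scatter). At this position, then, a group of 5 heavy atoms with 2 hydrogen-bond acceptors and a double bond outside the aromatic ring can stand where a single bromine stood without the half-life moving beyond the usual scatter. Nothing in the information at hand accounts for the size of this step.

The compounds shown leave open how the half-life responds to an amine or a carboxylic acid on this aromatic carbon, or to a longer chain in place of the ethyl of the ester. Compound 1, whose result is a limit of the assay, differs in more than one place from both others and so adds nothing on this position.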